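A few compounds are considered here, and "the series" means these few. Any claim that something is new, unique, unknown or untested is made for them only; others in the source may bear on it.

Measured in an ADME assay on microsomes from liver (Homo sapiens) for metabolic stability; on this read-out higher numbers stand for a longer-lived compound and lower numbers for a shorter-lived compound:
- compound 1 `COC[C@H](NC(=O)[C@H](CSC)NC(=O)c1cc(Cl)ccc1Cl)C(=O)N[C@@H](CC(C)C)C(=O)[C@@]1(C)CO1`: < 0.0834 h (a limit)
- compound 2 `COC[C@H](NC(=O)c1cc(C)on1)C(=O)N[C@@H](CSC)C(=O)N[C@@H](CC(C)C)C(=O)[C@@]1(C)CO1`: 0.283 h
- compound 3 `COC[C@H](NC(=O)[C@H](CSC)NC(=O)c1cc(C)on1)C(=O)N[C@@H](CC(C)C)C(=O)[C@@]1(C)CO1`: 0.382 h

Compound 3 gives 0.382 h, within the scatter of compound 2. The entry for compound 1, < 0.0834 h, is a limit of the assay. Compound 4 `CSC[C@H](NC(=O)c1cc(C)on1)C(=O)N[C@@H](CSC)C(=O)N[C@@H](CC(C)C)C(=O)[C@@]1(C)CO1` carries methylsulfanyl in place of methoxy on a saturated chain carbon, two bonds along the chain from an amide-type nitrogen and a carbonyl carbon. Within the data shown here, the one measured step, an at least 4.5-fold higher number from compound 1 to compound 3 (0.66 log units; beyond the scatter), changes a different place and starts from a limit, so it sets no size for this change. Among the measured compounds shown here, no measured step touches this place. The expectation therefore stays anchored on compound 3 at 0.382 h, with no shift beyond the scatter expected in this assay. The expected step is a 1.3-fold lower number from compound 3 to compound 4 (0.10 log units; within the scatter). For compound 4 the estimate is 0.3 h, with an expected range of 0.13 h to 0.65 h.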

Compound 4, half-life: 0.108 h
Beside the measured number, compound 4's estimate is 2.8-fold (0.44 log units) above it, outside the stated range (below it).
By their numbers in this assay, from the lowest: compound 4; then compounds 2 and 3 (each within the scatter of the next). At a limit, below all of these: compound 1.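

The side chain at this place, on a saturated chain carbon, two bonds along the chain from an amide-type nitrogen and a carbonyl carbon, now has a measured effect in this assay. Methylsulfanyl in place of methoxy gives a 2.6-fold lower number from compound 2 to compound 4 (0.42 log units; beyond the scatter) and also a 3.5-fold lower number from compound 3 to compound 4 (0.55 log units; beyond the scatter), so half-life shortens with this change. Nothing shown gives a cause for this step.

Still open, from the compounds shown here alone, is whether a plain ethyl chain, a hydroxyl or a longer ether at this place would retain the half-life seen with methoxy.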